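Swapping the Aryl Group on the Ether Carbon

A few compounds are considered here, and "the series" means these few. Any claim that something is new, unique, unknown or untested is made for them only; others in the source may bear on it.

Among the measured compounds shown here, compound 2 `C[C@@H](Oc1cc2oc(=O)n(CCC(=O)O)c2cc1Cl)c1ncccn1` gives 5.01 nM in an assay for inhibition of kynurenine 3-monooxygenase (Homo sapiens), read by mass spectrometry, with a stated time of 1 h (a higher number here means a weaker inhibitor, a lower number a stronger inhibitor), the higher of the two numbers measured so far, and compound 1 `C[C@@H](Oc1cc2oc(=O)n(CCC(=O)O)c2cc1Cl)c1ccc(Cl)cn1` sits close by with 3.16 nM, so that a 1.6-fold higher number from compound 1 to compound 2 (0.20 log units; within the scatter) lies within the scatter. Compound 3 `Cc1cccc([C@@H](C)Oc2cc3oc(=O)n(CCC(=O)O)c3cc2Cl)n1` differs from compound 2 by 6-methylpyridin-2-yl in place of pyrimidin-2-yl on a saturated chain carbon bound to an oxygen on an aromatic ring and a saturated chain carbon. For the measured compounds named here, only that one measured step bears on such a swap of one aromatic ring for another at this place, and it was small, so the expected step is a 1.3-fold lower number from compound 2 to compound 3 (0.10 log units; within the scatter) in this assay, not beyond the scatter. Compound 3 is therefore estimated at 4 nM, with a range of 1.5 nM to 12 nM.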

Compound 3, half-maximal inhibitory concentration in the kynurenine 3-monooxygenase assay: 5.01 nM
For compound 3 the middle estimate is 1.3-fold (0.10 log units) below the measured one; the measured number falls inside the stated range.
By their numbers in the kynurenine 3-monooxygenase assay, from the lowest: compounds 1, 2 and 3 (each within the scatter of the next).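

In the kynurenine 3-monooxygenase assay this place on the saturated chain carbon takes three different aromatic rings with no change beyond the scatter: no change at the digits printed from compound 2 to compound 3 (within the scatter) and a 1.6-fold higher number from compound 1 to compound 3 (0.20 log units; within the scatter). In a physicochemical assay for lipophilicity, read by HPLC, at pH 7.4 (on this read-out lower numbers stand for lower lipophilicity and higher numbers for higher lipophilicity), compound 2 gives 0.83 and compound 3 gives 2.12. The same swap that leaves inhibition in place shifts lipophilicity strongly in the physicochemical assay: the measured distribution coefficient of compound 2, 0.83, and of compound 3, 2.12, a number 1.29 log units higher (beyond the scatter). For this pair, then, lipophilicity moves widely while inhibition holds.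

The compounds shown leave open how a saturated ring such as cyclohexyl would read at this place in the kynurenine 3-monooxygenase assay, and whether an amine on the aromatic ring would hold inhibition as well.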